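Swapping Methoxy for Ethyl on Compound 2

This account rests on a few compounds, and the source may have more. Where it says the series, first, only, none or still open, it means among the compounds named here.

In a functional assay on A-375 cells (Homo sapiens) for inhibition, read by CCK-8 assay, with a stated time of 72 h, tested at 8 uM (on this read-out higher numbers stand for more inhibition of growth at the one concentration tested and lower numbers for less inhibition of growth), compound 1 (`Cc1cc(C)cc(SCc2ccc(/C=C/C(=O)Nc3ccccc3N)cc2)c1`) reaches 2.49% while compound 2 (`COc1ccc(SCc2ccc(C(=O)Nc3ccccc3N)cc2)cc1`) reaches 81.8% and stands highest of the two, a gap beyond the usual scatter. Compound 3 (`CCc1ccc(SCc2ccc(C(=O)Nc3ccccc3N)cc2)cc1`) carries ethyl in place of methoxy on an aromatic carbon. Within the data shown here, no measured pair shows this change alone, so the expectation starts from compound 2 at 81.8% and stays cautious. A small drop is expected, estimated as a number 6.8 percentage points lower from compound 2 to compound 3 (within the scatter) and possibly within the scatter. Compound 3 is estimated at 75% (expected range 52% to 92%).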

Compound 3, percent growth inhibition at one concentration: 71.1%
Compound 3: middle estimate off by 3.9 percentage points, on the high side, within the range that was stated.
By their numbers in this assay, from the lowest: compound 1; then compound 3; then compound 2.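

Swapping 4-methoxyphenyl for 4-ethylphenyl gives a number 10.7 percentage points lower from compound 2 to compound 3 (beyond the scatter) in this assay, so this position responds to the change, though only modestly. Methoxy is not essential for a high reading, since with ethyl, which has no oxygen, compound 3 still gives 71.1%. No measurement shown here accounts for the step. Still open, going by these compounds, is how an amine or a longer chain, such as propyl, would fare at this position. A single pair also cannot show whether the same swap would act alike on another core.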